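A few compounds are considered here, and "the series" means these few. Any claim that something is new, unique, unknown or untested is made for them only; others in the source may bear on it.

Compound 1 `COc1ccc2c(=O)c(/C=C/C(=O)Nc3cccc(C)c3)coc2c1` and compound 2 `COc1ccc2c(=O)c(/C=C/C(=O)Nc3ccccc3C)coc2c1` share one core and differ only in the group on the amide nitrogen. In a functional assay on Huh-7 cells (Homo sapiens) for inhibition, read by MTT assay, with a stated time of 48 h (a higher number here means a weaker inhibitor, a lower number a stronger inhibitor), compound 1 gives 15500 nM, and compound 2 gives 26900 nM. The step of a 1.7-fold higher number from compound 1 to compound 2 (0.24 log units; within the scatter) lies within the scatter, so the two numbers cannot really be told apart, with compound 2 nominally the larger. Compound 3 `COc1ccc2c(=O)c(/C=C/C(=O)NCc3ccc(F)cc3F)coc2c1` carries 2,4-difluorobenzyl in place of 2-methylphenyl on an amide-type nitrogen. For the measured compounds named here, no measured step tests a benzyl in place of a phenyl here, and the single step available was small, so the step of a 1.1-fold lower number from compound 2 to compound 3 (0.03 log units; within the scatter) is estimated to stay within the scatter. Compound 3 is therefore expected to give 25000 nM, with a range from 8000 nM to 80000 nM.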

Compound 3, half-maximal inhibitory concentration: > 100000 nM
Compound 3: only a limit was reported; the forecaster's own chance of this, stated with the estimate: 15%; middle value at least 4.0-fold (0.60 log units) away from the limit.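

Replacing a methylphenyl group with 2,4-difluorobenzyl on the amide nitrogen shifts the result in this assay, giving an at least 3.7-fold higher number from compound 2 to compound 3 (0.57 log units; beyond the scatter) and an at least 6.4-fold higher number from compound 1 to compound 3 (0.80 log units; beyond the scatter). The result for compound 3 is a limit of the assay, not a number: the limit of > 100000 nM in this assay, at which 1 of the 3 values shown sits. This position therefore responds to the group placed on it, which compound 1 and compound 2 alone did not show. Still open, as far as these compounds go, is whether the benzyl form or the two fluorines drive this step; an unsubstituted benzyl or a 2,4-difluorophenyl group on the same nitrogen could separate them.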